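Adding a 1,3-Oxazol-2-yl Ring to Compound 1

The compounds below may be only part of what the source reports. "The series", "measured", "known", "first", "only" and "open" are said of these compounds alone.

Compound 1, `CCOc1cc2oc(=O)n(CCC(=O)O)c2cc1Cl`: 398 nM
Compound 2, `C[C@@H](Oc1cc2onc(CCC(=O)O)c2cc1Cl)c1ccccn1`: 3.16 nM

Among the compounds with values here, in an assay on HEK293 cells for inhibition of kynurenine 3-monooxygenase (Homo sapiens), read by LC-MS, with a stated time of 20 h (on this read-out lower numbers stand for stronger inhibition and higher numbers for weaker inhibition), compound 1 gives 398 nM, the higher of the two numbers measured so far. Compound 2, built on a different core, gives 3.16 nM, a lower number by a margin beyond the usual scatter. Within the data shown here, the two compounds differ in more than one place, so no single step connects them and their values can only be set side by side.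

Compound 3, `C[C@@H](Oc1cc2oc(=O)n(CCC(=O)O)c2cc1Cl)c1ncco1`, is not yet measured. It keeps the core of compound 1 and differs from it by 1,3-oxazol-2-yl in place of hydrogen on a saturated chain carbon bound to an oxygen on an aromatic ring and a saturated chain carbon. Among the measured compounds shown here, no measured pair shows this change on its own. Compound 2, which also carries a ring on the saturated chain carbon bound to the oxygen, shows the lower value 3.16 nM, which suggests that such a ring is compatible with strong inhibition. Compound 3 is therefore expected to give a lower number than compound 1, with the expected step being a 10-fold lower number from compound 1 to compound 3 (1.00 log units; beyond the scatter). The estimate for compound 3 is 40 nM, in a range from 8 nM to 200 nM.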

Compound 3, half-maximal inhibitory concentration: 7940 nM
Estimate against measurement, compound 3: 200-fold (2.30 log units) below; the whole stated range lies below it.
By their numbers in this assay, from the lowest: compound 2; then compound 1; then compound 3.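

On the core of compound 1, the saturated chain carbon bound to an oxygen on an aromatic ring does not take a 1,3-oxazol-2-yl group without a heavy cost: in this assay the change gives a 20-fold higher number from compound 1 to compound 3 (1.30 log units; beyond the scatter), which means much weaker inhibition. Within the data shown here, this is the first direct reading of a change at this position, and it points the opposite way from the low number of compound 2. Compound 2 differs from compound 3 in more than one place, so a ring at this carbon cannot be called favourable or unfavourable in general.

As far as these compounds go, it remains open whether a phenyl ring or an amine in the same place would also raise the number on this core, or whether 1,3-oxazol-2-yl would do so on the core of compound 2. Nothing available explains the size of this step.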